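Series notes: cyano added on the benzyl ring

This account rests on a few compounds, and the source may have more. Where it says the series, first, only, none or still open, it means among the compounds named here.

Measured so far:
compound 1 `CN(C)CCCOc1c(OCc2ccccc2)cc(O)c2c(=O)cc(-c3ccccc3)oc12` gives 4950 nM
compound 2 `CN1CCN(CCCCOc2c(OCc3ccccc3)cc(O)c3c(=O)cc(-c4ccccc4)oc23)CC1` gives 1500 nM

Going by the values given here, in a functional assay on HepG2 cells (Homo sapiens) for cytotoxicity, read by MTT assay, with a stated time of 72 h (on this read-out lower numbers stand for stronger inhibition and higher numbers for weaker inhibition), compound 2 stands at the lowest of the two numbers, with compound 1 as its only neighbour at a higher number; the single measured step is a 3.3-fold lower number from compound 1 to compound 2 (0.52 log units; beyond the scatter), which concerns the amine on the chain and nothing else.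

Compound 3 `CN1CCN(CCCCOc2c(OCc3ccc(C#N)cc3)cc(O)c3c(=O)cc(-c4ccccc4)oc23)CC1` differs from compound 2 by cyano in place of hydrogen on an aromatic carbon. Among the compounds with values here, no measured step touches the benzyl group, so the step from compound 1 to compound 2 does not bear on this change, and there is nothing to point to either direction. The expected step is therefore no change at the digits printed from compound 2 to compound 3 (within the scatter), that is, nothing beyond the scatter, with a wide uncertainty. Compound 3 is expected to give 1500 nM in this assay, with a range from 450 nM to 5000 nM.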

Compound 3, half-maximal inhibitory concentration: 590 nM
Compound 3: the middle estimate sits 2.5-fold (0.41 log units) above what was measured; the measured number falls inside the stated range.
By their numbers in this assay, from the lowest: compound 3; then compound 2; then compound 1.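

In this assay the benzyl group now proves to be a second place in the series where a change moves the number, after the amine on the chain. Cyano in place of hydrogen, para to a large group on the benzyl ring, gives a 2.5-fold lower number from compound 2 to compound 3 (0.41 log units; beyond the scatter) with the chain and amine held the same. Going by these compounds alone, this position therefore accepts an added nitrile without loss, and the series so far has its lowest number with 4-cyanobenzyl on the core.

Going by these compounds, whether the step belongs to cyano itself or would also follow from fluorine, a methoxy group or a carboxylic acid at the same place stays open, as does whether it carries over to the dimethylamino chain of compound 1. No available data account for the step.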